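This account rests on a few compounds, and the source may have more. Where it says the series, first, only, none or still open, it means among the compounds named here.

Compound 1 `NN1C(=O)/C(=C/c2ccc(Cl)cc2)SC1=S` has been tested in an assay for inhibition of LL-diaminopimelate aminotransferase, chloroplastic (Arabidopsis thaliana) (a higher number here means a weaker inhibitor, a lower number a stronger inhibitor), and there compound 1 gives "not active" (no number reported). Two close relatives of its core have been run in the same test. Compound 2 `CC(=O)NN1C(=O)/C(=C/c2ccccc2)SC1=S` also gives "not active" (no number reported) in this assay. Compound 3 `O=C1/C(=C/c2cn(-c3ccccc3)nc2-c2cccs2)SC(=S)N1C1CCS(=O)(=O)C1`, which carries a larger group on the ring nitrogen and a different group on the double bond, is the only one of the three with a number: in this assay compound 3 gives 117000 nM, a very weak result. Compound 1 therefore stands among the compounds for which no inhibition could be quantified at all.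

Compound 4 `CCN1C(=O)/C(=C/c2ccc(Cl)cc2)SC1=S` is the next compound, not yet measured. It differs from compound 1 in one place: ethyl in place of amino on an amide-type nitrogen in a ring. Within the data shown here, no measured pair of this kind exists in this set, so the size of the step cannot be read from data; nothing among compounds 1, 2 and 3 suggests that such a small change would turn an inactive core into a measurable inhibitor, and a result at or beyond the weak level of compound 3 seems most plausible. Compound 4 is accordingly estimated to give 200000 nM in this assay, with a range from 50000 nM to 1000000 nM, and a considerable chance that only inactivity is reported.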

Compound 4, half-maximal inhibitory concentration: 200000 nM
The estimate for compound 4 equals the measured number at the digits printed; the measured number falls inside the stated range.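

Compound 1 gives "not active" (no number reported) and compound 4 gives 200000 nM, so no step can be read between them. The compounds shown leave open how other groups on the amide-type nitrogen in the ring would score. No measurement here offers an explanation for this result.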